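This account rests on a few compounds, and the source may have more. Where it says the series, first, only, none or still open, it means among the compounds named here.

Compound 2, `CC(C)[C@@H](NC(=O)CCCc1ccccc1)C(=O)N1CCC(c2ccc(Cl)cc2)CC1`, stands at the higher end of the two numbers measured: in an assay on THP-1 cells for displacement of a labelled ligand from C-C chemokine receptor type 1 (Homo sapiens) (on this read-out higher numbers stand for weaker inhibition and lower numbers for stronger inhibition), compound 2 gives 95 nM, while compound 1, `CC(C)[C@@H](NC(=O)c1cccc(F)c1)C(=O)N1CCC(c2ccc(Cl)cc2)CC1`, gives 24 nM. For the measured compounds named here, the only measured step, a 4.0-fold higher number from compound 1 to compound 2 (0.60 log units; beyond the scatter), involves a different change and offers no direct guide. Compound 3, `Cc1ccccc1CCC(=O)N[C@@H](C(=O)N1CCC(c2ccc(Cl)cc2)CC1)C(C)C`, differs from compound 2 by 2-methylphenyl in place of benzyl on a saturated chain carbon, two bonds along the chain from a carbonyl carbon. Going by the values given here, with no measured step bearing on this change, no step beyond the scatter is expected for no change at the digits printed from compound 2 to compound 3 (within the scatter). Compound 3 is therefore estimated at 95 nM, with an expected range from 40 nM to 250 nM.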

Compound 3, half-maximal inhibitory concentration: 19 nM
For compound 3 the middle estimate is 5.0-fold (0.70 log units) above the measured one; the whole stated range lies above it.
By their numbers in this assay, from the lowest: compounds 3 and 1 (each within the scatter of the next); then compound 2.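

For the compounds shown here, compound 3 shows that this position is sensitive to how the same atoms are joined: 2-methylphenyl in place of benzyl gives a 5.0-fold lower number from compound 2 to compound 3 (0.70 log units; beyond the scatter), a change that no earlier compound could show. It also shows that a chain amide can match the 3-fluorophenyl amide, with a 1.3-fold lower number from compound 1 to compound 3 (0.10 log units; within the scatter) and so no difference beyond the scatter. No evidence available here accounts for the shift. The compounds shown leave open whether a methoxy group or a chlorine in place of that methyl would hold the lower number, and whether a longer chain would keep it.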